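Hydroxy on the isopropyl group of compound 3

This account rests on a few compounds, and the source may have more. Where it says the series, first, only, none or still open, it means among the compounds named here.

Measured in a functional assay on HepG2 cells (Homo sapiens) for antiproliferative activity; a higher number here means a weaker inhibitor, a lower number a stronger inhibitor:
- compound 1 `CC[C@H](C)[C@H]1C(=O)N[C@H](Cc2ccc(O)c(Br)c2)C(=O)N[C@@H](C(C)(C)O)C(=O)O[C@H](c2ccccc2)[C@H](C)/C=C/C=C(\C)[C@H](OC)C/C=C(\C)C(=O)N1C` gives 5.21 nM
- compound 2 `CC[C@H](C)[C@H]1C(=O)N[C@H](Cc2ccc(O)c(Br)c2)C(=O)N[C@@H](C(C)(C)O)C(=O)O[C@H](c2ccccc2)[C@H](C)/C=C/C=C(\C)[C@H](OC)C[C@@H]2O[C@@]2(C)C(=O)N1C` gives 2.98 nM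
- compound 3 `CC[C@H](C)[C@H]1C(=O)N[C@H](Cc2cc(Cl)c(O)c(Cl)c2)C(=O)N[C@@H](C(C)C)C(=O)O[C@H](c2ccccc2)[C@H](C)/C=C/C=C(\C)[C@H](OC)C/C=C(\C)C(=O)N1C` gives 104 nM

Compound 3 has the highest number of the three, beyond the scatter from both compound 1 and compound 2. Compound 4 `CC[C@H](C)[C@H]1C(=O)N[C@H](Cc2cc(Cl)c(O)c(Cl)c2)C(=O)N[C@@H](C(C)(C)O)C(=O)O[C@H](c2ccccc2)[C@H](C)/C=C/C=C(\C)[C@H](OC)C/C=C(\C)C(=O)N1C` differs from compound 3 in one place (hydroxy in place of hydrogen on a saturated chain carbon bound to two saturated chain carbons and a saturated ring carbon), with hydroxy in place of hydrogen on a saturated chain carbon bound to two saturated chain carbons and a saturated ring carbon: isopropyl to 1-hydroxy-1-methylethyl. For the measured compounds named here, no measured pair shows this change alone. Compound 1 (5.21 nM) and compound 2 (2.98 nM) carry 1-hydroxy-1-methylethyl, yet both also differ from compound 3 elsewhere. A lower number, beyond the scatter, is expected in this assay. The expected step is an 8.7-fold lower number from compound 3 to compound 4 (0.94 log units; beyond the scatter). For compound 4 the estimated value is 12 nM, with an expected range of 4 nM to 40 nM.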

Compound 4, half-maximal inhibitory concentration: 2.75 nM
For compound 4 the middle estimate is 4.4-fold (0.64 log units) above the measured one; the whole stated range lies above it.
By their numbers in this assay, from the lowest: compounds 4, 2 and 1 (each within the scatter of the next); then compound 3.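

In this assay the change from isopropyl to 1-hydroxy-1-methylethyl can now be read alone, as a 38-fold lower number from compound 3 to compound 4 (1.58 log units; beyond the scatter) and a large step. With 1-hydroxy-1-methylethyl present, 3,5-dichloro-4-hydroxyphenyl in place of 3-bromo-4-hydroxyphenyl gives a 1.9-fold lower number from compound 1 to compound 4 (0.28 log units; within the scatter) and so does not separate the two groups. No measurement on hand explains the effect of the hydroxy.

Still open, going by these compounds, is whether methoxy or an amine on the same carbon would keep the number as low as hydroxy does. Also open, on these data alone, is whether the step holds with 3-bromo-4-hydroxyphenyl in the molecule.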